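The source may report more compounds than this note shows. Statements on the series, on what has been measured and on what is new or still open speak of the compounds shown alone.

Measured so far:
- compound 1, `COc1cc([C@@H]2c3[nH]c4ccccc4c3C[C@H]3C(=O)N4[C@H](c5cc(OC)c(OCc6ccccc6)c(OC)c5)c5[nH]c6ccccc6c5C[C@H]4C(=O)N23)cc(OC)c1OCc1ccccc1`: 54.5%
- compound 2, `COc1cc([C@H]2c3[nH]c4ccccc4c3C[C@@H]3C(=O)N4[C@@H](c5cc(OC)c(O)c(OC)c5)c5[nH]c6ccccc6c5C[C@@H]4C(=O)N23)cc(OC)c1O`: 15.7%

In a functional assay on PC-3 cells (Homo sapiens) for cytotoxicity, tested at 100 uM (on this read-out higher numbers stand for a weaker effect at the one concentration tested and lower numbers for a stronger effect), compound 2 gives 15.7%, the lower of the two numbers obtained. Going by the values given here, the other measured compound, compound 1, gives 54.5% in this assay, a number well above that of compound 2, beyond the scatter of repeated measurements; no step between the two is worked out here, so only the two numbers themselves are compared.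

The next compound in the series is compound 3, `COc1cc([C@@H]2c3[nH]c4ccccc4c3C[C@H]3C(=O)N4[C@H](c5cc(OC)c(O)c(OC)c5)c5[nH]c6ccccc6c5C[C@H]4C(=O)N23)cc(OC)c1O`, which has not been measured in this assay. Compared with compound 2 the change is the two compounds have the same atoms and bonds and differ only in configuration as drawn: 4 of 4 stereo elements differ (all stereocentres are inverted: mirror images); a stereocentre at a saturated ring carbon is drawn S in compound 2 and R in compound 3; a stereocentre at a saturated ring carbon is drawn R in compound 2 and S in compound 3; a stereocentre at a saturated ring carbon is drawn S in compound 2 and R in compound 3; a stereocentre at a saturated ring carbon is drawn R in compound 2 and S in compound 3.

With nothing measured for this kind of change within the series, the size and direction of the step cannot be read from the data. A mirror image can behave like its partner or differ from it considerably, so a step beyond the scatter in either direction is possible, with a weaker effect at the single concentration considered somewhat more likely than a stronger one. The step from compound 2 to compound 3 is expected to be a number 19.3 percentage points higher from compound 2 to compound 3 (beyond the scatter). Compound 3 is therefore estimated at 35% in this assay, within a wide range from 10% to 75%.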

Compound 3, a percentage reported as activity, at one concentration (the size of the read-out at that concentration, not a potency): 1.6%
For compound 3 the middle estimate is 33.4 percentage points above the measured one, and the stated range ends above it.
By their numbers in this assay, from the lowest: compound 3; then compound 2; then compound 1.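

In this assay the series now has its first readable step, a number 14.1 percentage points lower from compound 2 to compound 3 (beyond the scatter), which runs towards a stronger effect at the one concentration tested. This step can be assigned to configuration alone, since nothing else changes: the fact that compounds 2 and 3 differ only in the configuration as drawn. On this read-out the two mirror images are therefore not interchangeable, so configuration has to be tracked as a variable in its own right for this core, although a single concentration gives a difference in effect size and not in potency.

Which of the four inverted stereocentres accounts for the step remains open, as does whether inverting only some of them would give a number nearer to compound 2 or to compound 3. As far as these compounds go, it is also open how compound 3 would respond if an amine or a carboxylic acid took the place of its hydroxyl groups, and whether such a change would leave the preference for this configuration intact.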